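Swapping the sulfonyl aryl group in a liver-stability series

This account rests on a few compounds, and the source may have more. Where it says the series, first, only, none or still open, it means among the compounds named here.

Measured so far:
- compound 1, `Cn1cnc(S(=O)(=O)N(Cc2ccc(C#N)cc2)C2Cc3cc(C#N)ccc3N(Cc3cncn3C)C2)c1`, gives 3 h in an in vitro ADME assay on microsomes from liver (Mus musculus) for metabolic stability; a higher number here means that the compound lasts longer, a lower number that the compound disappears faster
- compound 2, `Cn1cnc(S(=O)(=O)N(CC(=O)OC(C)(C)C)C2Cc3cc(C#N)ccc3N(Cc3cncn3C)C2=O)c1`, gives 21 h in this assay
- compound 3, `Cn1cncc1CN1C(=O)C(N(CC(=O)NC(C)(C)C)S(=O)(=O)c2cccc(F)c2)Cc2cc(C#N)ccc21`, gives 31 h in this assay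

Compound 3 sits at the upper end of these three numbers. Its nearest neighbour is compound 2, whose number lies within the usual scatter of compound 3, so the two cannot be told apart with confidence. Compound 1 stands far below compound 3, well beyond the scatter.

Compound 4, `Cn1cnc(S(=O)(=O)N(CC(=O)NC(C)(C)C)C2Cc3cc(C#N)ccc3N(Cc3cncn3C)C2=O)c1`, has not yet been measured. It differs from compound 3 in one place: 1-methyl-1H-imidazol-4-yl in place of 3-fluorophenyl on a sulfonyl sulfur. Compound 2 already carries a 1-methyl-1H-imidazol-4-yl on its sulfonyl sulfur and gives 21 h, a number indistinguishable from compound 3. On that basis the step of a 1.3-fold lower number from compound 3 to compound 4 (0.13 log units; within the scatter) is expected to be small, if anything slightly downward, and not beyond the scatter. Compound 4 is therefore estimated at 23 h, with a plausible range from 11 h to 45 h.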

Compound 4, half-life: 144 h
The estimate for compound 4 lay 6.3-fold (0.80 log units) below the measured number; measured number outside the range, above it.
By their numbers in this assay, from the lowest: compound 1; then compounds 2 and 3 (each within the scatter of the next); then compound 4.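

On the sulfonyl sulfur, 1-methyl-1H-imidazol-4-yl in place of 3-fluorophenyl gives a 4.6-fold higher number from compound 3 to compound 4 (0.67 log units; beyond the scatter) in this assay, so the group at this position can change how long a compound lasts in this test. The same 1-methyl-1H-imidazol-4-yl group is present on both sides of the other step, where (tert-butyl)amino in place of tert-butoxy on a carbonyl carbon gives a 6.9-fold higher number from compound 2 to compound 4 (0.84 log units; beyond the scatter), so the number reached with this sulfonyl group also depends on what sits on that carbonyl carbon. Nothing available here explains either step.

The compounds shown leave open whether a plain phenyl or a pyridine ring on the sulfonyl sulfur would reach a similar number. They also leave open whether a carboxylic acid or a methylamino group on the carbonyl carbon would keep it.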